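The compounds below may be only part of what the source reports. "The series", "measured", "known", "first", "only" and "open" are said of these compounds alone.

Measured so far:
compound 1, `Clc1ccc(-c2csc(N/N=C/c3ccc(-n4ccnc4)cc3)n2)cc1`, 32.1%
compound 2, `Brc1ccc(-c2csc(N/N=C/c3ccc(-n4ccnc4)cc3)n2)cc1`, 36.8%
compound 3, `Clc1ccc(-c2csc(N/N=C/c3ccc(-n4cncn4)cc3)n2)cc1`, 28.4%

All three were tested in an ADME assay on THP-1 cells (Homo sapiens) for cytotoxicity, read by MTT assay, tested at 50 ug/mL; on this read-out lower numbers stand for less inhibition and higher numbers for more inhibition at the one concentration tested (going by the name of the read-out). Compound 1 and compound 2 differ in one place only: bromo in place of chloro on an aromatic carbon. That change gave a number 4.7 percentage points higher from compound 1 to compound 2 (within the scatter). Compound 1 and compound 3 differ in their cores: 1H-1,2,4-triazol-1-yl in place of 1H-imidazol-1-yl on an aromatic carbon. This change gave a number 3.7 percentage points lower from compound 1 to compound 3 (within the scatter). Compound 3 has the lowest of the three numbers, yet the other two stand within the scatter of it, so no order among the three can be read from these numbers.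

Compound 4, `Brc1ccc(-c2csc(N/N=C/c3ccc(-n4cncn4)cc3)n2)cc1`, has not yet been measured in this assay. It differs from compound 3 in one place: bromo in place of chloro on an aromatic carbon. This is the same change that was made from compound 1 to compound 2, here set on the core of compound 3, which differs from the core of compound 1 in the way already described. Because the same change gave a number 4.7 percentage points higher from compound 1 to compound 2 (within the scatter), the expected step is a number 4.6 percentage points higher from compound 3 to compound 4 (within the scatter), a step that would lie within the scatter. On that basis compound 4 is estimated to give 33% in this assay, with an expected range from 23% to 43%.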

Compound 4, a percentage reported as inhibition, at one concentration (the size of the read-out at that concentration, not a potency): 32.6%
For compound 4 the middle estimate is 0.4 percentage points above the measured one; the range from low to high includes it.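

In this assay, bromo in place of chloro gave a number 4.2 percentage points higher from compound 3 to compound 4 (within the scatter), and set beside the earlier case, the change reads alike on both cores: the same change on two cores in this assay, a number 4.7 percentage points higher (within the scatter) from compound 1 to compound 2 and a number 4.2 percentage points higher (within the scatter) from compound 3 to compound 4, 0.5 percentage points apart, within the scatter of two such steps. Looked at the other way, 1H-1,2,4-triazol-1-yl in place of 1H-imidazol-1-yl gave a number 4.2 percentage points lower from compound 2 to compound 4 (within the scatter), which also agrees with the same change made on the chloro compounds: the same change on two cores in this assay, a number 3.7 percentage points lower (within the scatter) from compound 1 to compound 3 and a number 4.2 percentage points lower (within the scatter) from compound 2 to compound 4, 0.5 percentage points apart, within the scatter of two such steps. The two changes therefore carry from one core to the other with no sign that one alters the size of the other, but every step here lies within the scatter, so this does not show that either change has a real effect, and these four compounds cannot show that the agreement would hold on any further core.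

All four compounds carry only chloro or bromo on the six-membered aromatic ring of carbon only, so they leave open whether an amine or a methoxy group in that place would move the number beyond the scatter. They also leave open whether a carboxylic acid in place of the 1H-imidazol-1-yl or 1H-1,2,4-triazol-1-yl group would do so.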